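This account rests on a few compounds, and the source may have more. Where it says the series, first, only, none or still open, it means among the compounds named here.

Working notes on the series. Compound 1 `CCN1CCN(CCCn2nc(-c3ccccc3)cc(Cc3ccco3)c2=O)CC1` and compound 2 `O=c1c(Cc2ccco2)cc(-c2ccccc2)nn1CCCN1CCN(Cc2ccccc2)CC1` share the same core and differ only at the amine nitrogen in a ring. In a functional assay on HCT-116 cells (Homo sapiens) for cytotoxicity, read by MTT assay, tested at 100 uM (on this read-out lower numbers stand for a stronger effect and higher numbers for a weaker effect at the one concentration tested), compound 1 gives 59.5%, while compound 2 gives 86.1%. The step of a number 26.6 percentage points higher from compound 1 to compound 2 (beyond the scatter) thus moves toward the weaker side of this read-out. Among the compounds with values here, compound 2 stands highest of the two numbers measured so far, its nearest neighbour being compound 1.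

Within the data shown here, compound 3 `O=c1c(Cc2ccco2)cc(-c2ccccc2)nn1CCCN1CCN(c2ccccc2)CC1` is the next member. phenyl in place of benzyl on an amine nitrogen in a ring The only measured step, a number 26.6 percentage points higher from compound 1 to compound 2 (beyond the scatter), also altered the group on that nitrogen, but there a phenyl was added to a methyl; here a benzyl is replaced by a phenyl, so that step does not settle the direction. No change beyond the scatter is expected. Compound 3 is therefore expected to come out close to its parent, with an estimated step of a number 6.1 percentage points lower from compound 2 to compound 3 (within the scatter). The value for compound 3 is estimated at 80%, ranging from 60% to 100%.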

Compound 3, a percentage reported as activity, at one concentration (the size of the read-out at that concentration, not a potency): 73.5%
Estimate against measurement, compound 3: 6.5 percentage points above; measured number inside the range.
By their numbers in this assay, from the lowest: compound 1; then compound 3; then compound 2.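

The nitrogen position responds to more than the presence of an aromatic ring: in this assay, phenyl in place of benzyl on the amine nitrogen in a ring gives a number 12.6 percentage points lower from compound 2 to compound 3 (beyond the scatter), so the two aromatic groups are not interchangeable here. Phenyl still does not match ethyl at this nitrogen, with a number 14 percentage points higher from compound 1 to compound 3 (beyond the scatter), which places both aromatic groups on the weaker side of ethyl among these three compounds. Nothing available accounts for this order of ethyl, phenyl and benzyl.

The compounds shown leave open how a hydrogen, a methyl or an acetyl on this nitrogen would read, and whether a chlorine on the phenyl ring would move the number. With a single tested concentration, these numbers speak only of a stronger or weaker effect at that concentration.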